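Adding a fluoro to compound 3

The compounds below may be only part of what the source reports. "The series", "measured", "known", "first", "only" and "open" are said of these compounds alone.

Compound 1 `C=C1C=CC(=O)[C@@H]2[C@H](Cc3ccc(OCOC)c(F)c3)CC[C@H]12`: 40 nM
Compound 2 `C=C1C=CC(=O)[C@@H]2[C@H](Cc3ccc(OC)c(F)c3)CC[C@H]12`: 1.68 nM
Compound 3 `C=C1C=CC(=O)[C@@H]2[C@H](Cc3ccc(O)cc3)CC[C@H]12`: 30.8 nM

In a functional assay on A-375 cells (Homo sapiens) for antiproliferative activity, with a stated time of 72 h (on this read-out higher numbers stand for weaker inhibition and lower numbers for stronger inhibition), compound 3 gives 30.8 nM. That lies within the usual scatter of compound 1 and well above compound 2, which gives 1.68 nM. Compound 4 `C=C1C=CC(=O)[C@@H]2[C@H](Cc3ccc(O)c(F)c3)CC[C@H]12` is compound 3 with a single change: fluoro in place of hydrogen on an aromatic carbon. Going by the values given here, no measured step isolates this fluoro in place of hydrogen. Among the compounds with values here, the one step available, a 24-fold lower number from compound 1 to compound 2 (1.38 log units; beyond the scatter), is large, but both of its compounds already carry the fluoro, so it bears on the change only indirectly. It does show how far the numbers can spread among compounds with a fluoro, since compound 1 gives 40 nM and compound 2 gives 1.68 nM. Compound 2 also differs from compound 4 on the oxygen, so its low number cannot simply be carried over. A modest move towards a lower number is therefore expected, far smaller than the measured step. The expected change is a 2.6-fold lower number from compound 3 to compound 4 (0.41 log units; beyond the scatter). For compound 4 the estimated value is 12 nM, with an expected range of 2.5 nM to 45 nM.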

Compound 4, half-maximal inhibitory concentration: 98.4 nM
The estimate for compound 4 lay 8.2-fold (0.91 log units) below the measured number; measured number above the stated range.
By their numbers in this assay, from the lowest: compound 2; then compounds 3 and 1 (each within the scatter of the next); then compound 4.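

In this assay, fluoro in place of hydrogen on this aromatic carbon, ortho to a hydroxy group, weakens inhibition, with a 3.2-fold higher number from compound 3 to compound 4 (0.50 log units; beyond the scatter). With the fluoro kept, what sits on the neighbouring oxygen also matters: hydrogen in place of methyl gives a 59-fold higher number from compound 2 to compound 4 (1.77 log units; beyond the scatter), a far larger shift, and hydrogen in place of methoxymethyl gives a 2.5-fold higher number from compound 1 to compound 4 (0.39 log units; beyond the scatter). Compound 4 therefore has the weakest inhibition of the four, so the low number of the methoxy compound does not carry over to the free hydroxy group.

Nothing measured here accounts for these shifts. Still open, going by these compounds, is whether a chloro on the same aromatic carbon would behave like the fluoro, and whether the fluoro would raise the number in the same way with methyl on the oxygen.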